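This account rests on a few compounds, and the source may have more. Where it says the series, first, only, none or still open, it means among the compounds named here.

Within the data shown here, compound 3 `Cc1ccc2c(c1)C[C@@H](O)C[C@@H](c1ccccc1Cl)N2` sits at the low end of the numbers measured so far in an ADME assay on Vero cells (Chlorocebus sabaeus) for cytotoxicity, read by MTT assay, with a stated time of 72 h (a higher number here means that more compound is tolerated, a lower number that less compound is tolerated), where compound 3 gives 82400 nM. Its nearest neighbour is compound 1 `O[C@@H]1Cc2cc(Cl)ccc2N[C@H](c2ccccc2)C1`, which in this assay gives 191000 nM. Compound 2 `O[C@@H]1Cc2ccccc2N[C@H](c2ccccc2Cl)C1` is reported in this assay only as > 300000 nM, which is a limit rather than a number, namely (the limit of > 300000 nM in this assay, at which 1 of the 3 values shown sits).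

Compound 4 `O[C@@H]1Cc2cc(Cl)ccc2N[C@H](c2ccccc2Cl)C1` has not yet been measured. It differs from compound 3 in one place: chloro in place of methyl on an aromatic carbon. Among the measured compounds shown here, the only measured step that touches this position is the one from compound 2 to compound 3, where adding methyl gave an at least 3.6-fold lower number from compound 2 to compound 3 (0.56 log units; beyond the scatter). A chloro at the same position is already present in compound 1, whose number stands between those of compound 3 and compound 2. Taken together, swapping methyl for chloro is expected to move the number only modestly, if at all, most likely staying within the scatter of compound 3 or edging slightly upward.

Compound 4 is therefore estimated to give 100000 nM, with a likely range from 50000 nM to 250000 nM. That expectation amounts to a step of a 1.2-fold higher number from compound 3 to compound 4 (0.08 log units; within the scatter), an estimate to be checked against the measurement.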

Compound 4, half-maximal cytotoxic concentration: 106000 nM
Compound 4: middle estimate off by 1.1-fold (0.03 log units), on the low side; the measured number falls inside the stated range.
By their numbers in this assay, from the lowest: compounds 3, 4 and 1 (each within the scatter of the next, the first and the last beyond it). At a limit, above all of these: compound 2.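

Methyl and chloro on this aromatic carbon give numbers that cannot be told apart in this assay, with a 1.3-fold higher number from compound 3 to compound 4 (0.11 log units; within the scatter), and chloro in place of hydrogen on a different aromatic carbon also stays within the scatter, with a 1.8-fold lower number from compound 1 to compound 4 (0.26 log units; within the scatter). Going from hydrogen to chloro on the first carbon gives an at least 2.8-fold lower number from compound 2 to compound 4 (0.45 log units; beyond the scatter), in the same direction as an at least 3.6-fold lower number from compound 2 to compound 3 (0.56 log units; beyond the scatter), so among these compounds the lower number does not depend on methyl alone: either group in place of hydrogen there goes with less compound being tolerated. Both of these steps start from a value for compound 2 that is a limit and not a number: the limit of > 300000 nM in this assay, at which 1 of the 4 values shown sits.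

On these data alone, only hydrogen, methyl and chloro appear on this aromatic carbon, so it remains open how an amine, a carboxylic acid or a longer chain such as propyl would behave there. As far as these compounds go, the full size of the steps from compound 2 also remains open, and with it whether methyl and chloro would still match in other compounds with a different core.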